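A few compounds are considered here, and "the series" means these few. Any claim that something is new, unique, unknown or untested is made for them only; others in the source may bear on it.

Three amides of the shared core have been measured in an assay on SH-EP1 cells for agonist activity at Neuronal acetylcholine receptor; alpha4/beta2 (Homo sapiens), read by FLIPR and calcium flux; a lower number here means a smaller maximal response, a higher number a larger maximal response. Compound 1 `CC(=O)N1CC2CC(C1)N2` gives 94%. Compound 2 `CCC(=O)N1CC2CC(C1)N2` gives 98% in this assay. Compound 3 `CCCC(=O)N1CC2CC(C1)N2` gives 120% in this assay. The step of a number 4 percentage points higher from compound 1 to compound 2 (within the scatter) is small, while the steps of a number 26 percentage points higher from compound 1 to compound 3 (beyond the scatter) and a number 22 percentage points higher from compound 2 to compound 3 (beyond the scatter) are larger. Compound 3 therefore stands highest of the three measured numbers, with compound 2 nearest and compound 1 furthest, both gaps beyond the scatter.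

Compound 4 `O=C(CC1C=CCC1)N1CC2CC(C1)N2` is the next member. It differs from compound 3 thus: cyclopent-2-en-1-yl in place of ethyl on a saturated chain carbon bound to a carbonyl carbon. Because the steps of a number 26 percentage points higher from compound 1 to compound 3 (beyond the scatter) and a number 22 percentage points higher from compound 2 to compound 3 (beyond the scatter) raised the maximal response as the chain at this place grew, the larger group entering in compound 4 is expected to hold the response at or somewhat above that of compound 3. Among the compounds with values here, no measured compound carries a ring at this place, so the expectation is loosely held. The step of a number 5 percentage points higher from compound 3 to compound 4 (within the scatter) is the expected outcome. Compound 4 is estimated to reach 125%, within 95% to 155%, in this assay.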

Compound 4, largest response reached (Emax), in percent of the reference or control that the assay uses: 89%
Compound 4: the middle estimate sits 36 percentage points above what was measured; measured number outside the range, below it.
By their numbers in this assay, from the lowest: compounds 4, 1 and 2 (each within the scatter of the next); then compound 3.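

In this assay, the gain seen as the chain grew does not carry over to a ring: cyclopent-2-en-1-yl in place of ethyl on a saturated chain carbon bound to a carbonyl carbon gives a number 31 percentage points lower from compound 3 to compound 4 (beyond the scatter). Compound 4 is not separated from the smaller amides, with a number 9 percentage points lower from compound 2 to compound 4 (within the scatter) and a number 5 percentage points lower from compound 1 to compound 4 (within the scatter), so among these four amides the maximal response does not simply follow the size of the group at this place, and compound 4 goes against that reading. Nothing available accounts for this result.

Going by these compounds, it remains open whether the loss goes with the ring itself or with its double bond, a question that a saturated cyclopentyl group at this place would address. Also open, on these data alone, is whether an unbranched butyl or pentyl group would keep the response seen for compound 3.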